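The compounds below may be only part of what the source reports. "The series", "measured", "known", "first", "only" and "open" are said of these compounds alone.

Of the compounds shown here, two with a shared core have been measured. In a functional assay, with a stated time of 6 min (a lower number here means a stronger inhibitor, a higher number a weaker inhibitor), compound 1 `FC(F)(F)c1cccc(NCn2nc(-c3ccc4c(c3)OCCO4)oc2=S)c1` gives 7620 nM, and compound 2 `S=c1oc(-c2ccc3c(c2)OCCO3)nn1CNc1ccccc1Br` gives 12700 nM, the highest of the two numbers; the gap between them lies within the scatter, so the two read as alike. Compound 3 `O=[N+]([O-])c1cccc(NCn2nc(-c3ccc4c(c3)OCCO4)oc2=S)c1` differs from compound 2 by 3-nitrophenyl in place of 2-bromophenyl on an amine nitrogen. Among the compounds with values here, no measured pair shows this change, so the expected step is small: compound 3 is estimated at 8500 nM, with a range of 3000 nM to 25000 nM. The expected step of a 1.5-fold lower number from compound 2 to compound 3 (0.17 log units; within the scatter) would stay within the scatter.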

Compound 3, half-maximal inhibitory concentration: 8870 nM
Compound 3: the middle estimate sits 1.0-fold (0.02 log units) below what was measured, and the stated range covers the measured number.
By their numbers in this assay, from the lowest: compounds 1, 3 and 2 (each within the scatter of the next).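

In this assay, within the data shown here, the first change at a single place, nitro in place of trifluoromethyl on an aromatic carbon, gives a 1.2-fold higher number from compound 1 to compound 3 (0.07 log units; within the scatter) and so leaves the reading unmoved. The swap of 2-bromophenyl for 3-nitrophenyl on the amine nitrogen gives a 1.4-fold lower number from compound 2 to compound 3 (0.16 log units; within the scatter) and likewise leaves all three compounds reading as alike, so these ring groups are interchangeable here. Nothing available explains why these groups read alike.

Still open, from the compounds shown here alone, is whether a phenyl ring carrying an amine or a carboxylic acid would read the same. A saturated ring or a longer chain on that nitrogen is equally untested among the compounds shown.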